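Thiophene attachment point on a pyridine core

This account rests on a few compounds, and the source may have more. Where it says the series, first, only, none or still open, it means among the compounds named here.

Three compounds share a pyridine-based core and were tested in a functional assay on HCT-15 cells (Homo sapiens) for cytotoxicity, in the presence of a further agent that is not named here; on this read-out higher numbers stand for weaker inhibition and lower numbers for stronger inhibition. Compound 1 `Clc1cccc(-c2cc(-c3ccc(Cl)o3)cc(-c3cccs3)n2)c1` gives 15500 nM in this assay. Compound 2 `Clc1ccc(-c2cc(-c3ccc(Cl)o3)cc(-c3cccs3)n2)cc1` gives 14200 nM in this assay, and the change a 1.1-fold lower number from compound 1 to compound 2 (0.04 log units; within the scatter) stays within the scatter. Compound 3 `Clc1ccc(-c2cc(-c3ccsc3)nc(-c3ccco3)c2)o1` differs from these two in bearing a furan-2-yl group and a thiophen-3-yl group in place of a chlorophenyl and a thiophen-2-yl group. For compound 3 this assay reports only a limit, > 50000 nM, so compound 3 stands at the weak end of the numbers shown, as recorded in the limit of > 50000 nM in this assay, at which 1 of the 3 values shown sits.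

Compound 4 `Clc1ccc(-c2cc(-c3ccco3)nc(-c3cccs3)c2)o1` has not yet been measured. It differs from compound 3 in one place: thiophen-2-yl in place of thiophen-3-yl on an aromatic carbon. Among the measured compounds shown here, no measured step covers this change; the only measured step, from compound 1 to compound 2, concerns a chlorophenyl group and lies within the scatter. He therefore expects no step beyond the scatter, that is a step that the limit leaves unreadable from compound 3 to compound 4, and estimates compound 4 at 60000 nM, between 20000 nM and 150000 nM in this assay.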

Compound 4, half-maximal inhibitory concentration: > 50000 nM
Compound 4 gave a limit, no number; the forecaster's own chance of this, stated with the estimate: 60%; the middle value is on the limit's open side.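

With thiophen-2-yl in place of thiophen-3-yl, compound 4 stays at a limit of this assay, as compound 3 does, so the steps between these limits cannot be read and this change brings no measured number: the limit of > 50000 nM in this assay, at which 2 of the 4 values shown sit.

With thiophen-2-yl kept, furan-2-yl in place of a chlorophenyl group gives an at least 3.5-fold higher number from compound 2 to compound 4 (0.54 log units; beyond the scatter) and an at least 3.2-fold higher number from compound 1 to compound 4 (0.50 log units; beyond the scatter). Thiophen-2-yl alone therefore does not bring a measured number in this assay, and the place now held by furan-2-yl is where a readable change appears.

As far as these compounds go, whether the thiophene attachment point matters at all stays open, since any difference may lie hidden past the limit. Also open, from the compounds shown here alone, is whether an amine or a carboxylic acid at the place held by furan-2-yl would give a measured number.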